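The source may report more compounds than this note shows. Statements on the series, on what has been measured and on what is new or still open speak of the compounds shown alone.

Measured in a functional assay on A2780 cells (Homo sapiens) for antiproliferative activity, read by fluorescence, with a stated time of 72 h; on this read-out higher numbers stand for weaker inhibition and lower numbers for stronger inhibition:
compound 1 `CC(C)(C)C(=O)N1Cc2c(NC(=O)c3ccncc3)n[nH]c2C1(C)C` gives 110 nM
compound 2 `CN1CCC(C(=O)N2Cc3c(NC(=O)c4ccsc4)n[nH]c3C2(C)C)CC1` gives 140 nM
compound 3 `CC(C)CC(=O)Nc1n[nH]c2c1CN(C(=O)C1CCN(C3CC3)CC1)C2(C)C` gives 320 nM

Compound 2 stands second highest of the three numbers. Its nearest neighbour is compound 1, whose value lies within the scatter of that of compound 2; compound 3 lies furthest off, beyond the scatter.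

Compound 4 `CN1CCC(C(=O)N2Cc3c(NC(=O)c4ccc(Cl)cc4)n[nH]c3C2(C)C)CC1` differs from compound 2 in one place: 4-chlorophenyl in place of thiophen-3-yl on a carbonyl carbon. Going by the values given here, no measured pair differs in this way, so no step of this kind is known. Compound 1 and compound 2, which carry different aromatic amides on the same core, give values within the scatter of each other, so for this assay no step beyond the scatter is expected in either direction.

Compound 4 is expected to give about 150 nM in this assay, with a range of 60 nM to 400 nM. The expected step of a 1.1-fold higher number from compound 2 to compound 4 (0.03 log units; within the scatter) should stay within the scatter.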

Compound 4, half-maximal inhibitory concentration: 120 nM
Compound 4: middle estimate off by 1.3-fold (0.10 log units), on the high side; low and high end bracket the measured number.
By their numbers in this assay, from the lowest: compounds 1, 4 and 2 (each within the scatter of the next); then compound 3.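

In this assay, 4-chlorophenyl in place of thiophen-3-yl on a carbonyl carbon gives a 1.2-fold lower number from compound 2 to compound 4 (0.07 log units; within the scatter). Going by these compounds alone, this is the first single-change pair, and it shows that this position accepts a chlorine-bearing six-membered aromatic ring in place of a five-membered sulfur-containing one with no step beyond the scatter, though this rests on one pair. No available evidence bears on the reason for this result.

Still open, going by these compounds, is whether the number would hold with a carboxylic acid or a dimethylamino group in place of the chlorine on the phenyl ring.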